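The source may report more compounds than this note shows. Statements on the series, on what has been measured and on what is new or still open speak of the compounds shown alone.

Values so far in a functional assay on TM4 cells (Mus musculus) for cytotoxicity, read by MTT assay, with a stated time of 72 h; on this read-out lower numbers stand for stronger inhibition and higher numbers for weaker inhibition
- compound 1 `Nc1nc(Nc2ccccc2)sc1C(=O)c1cccc(F)c1` gives 5100 nM
- compound 2 `Nc1nc(Nc2ccc(S(N)(=O)=O)cc2)sc1C(=O)c1ccccc1[N+](=O)[O-]` gives 16000 nM
- compound 3 `Nc1nc(Nc2ccc(S(N)(=O)=O)cc2)sc1C(=O)c1cccc(F)c1` gives 4800 nM

Compound 3 sits at the low end of these numbers, level with compound 1 (a 1.1-fold lower number from compound 1 to compound 3 (0.03 log units; within the scatter)). Compound 4 `COc1cccc(C(=O)c2sc(Nc3ccc(S(N)(=O)=O)cc3)nc2N)c1` has methoxy in place of fluoro on an aromatic carbon, meta to a large group (methoxy in place of fluoro on an aromatic carbon). Going by the values given here, no measured step exchanges fluoro itself. The nearest evidence is the change of the aryl group on the carbonyl carbon, which was modest (a 3.3-fold lower number from compound 2 to compound 3 (0.52 log units; beyond the scatter)). The sulfamoyl step lies elsewhere in the molecule. On these data alone, no step beyond the scatter is therefore expected in this assay, and the direction stays open. The expected step is a 1.3-fold higher number from compound 3 to compound 4 (0.10 log units; within the scatter). Compound 4 is estimated at 6000 nM, with an expected range from 2500 nM to 14000 nM.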

Compound 4, half-maximal inhibitory concentration: 6400 nM
Compound 4: middle estimate off by 1.1-fold (0.03 log units), on the low side; low and high end bracket the measured number.
By their numbers in this assay, from the lowest: compounds 3, 1 and 4 (each within the scatter of the next); then compound 2.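

In this assay, going by these compounds alone, this is the first exchange of the substituent itself on this ring, and methoxy in place of fluoro, meta to a large group, gives a 1.3-fold higher number from compound 3 to compound 4 (0.12 log units; within the scatter). The 3-methoxyphenyl compound also keeps a gap to the 2-nitrophenyl compound, with a 2.5-fold lower number from compound 2 to compound 4 (0.40 log units; beyond the scatter). No accompanying data explain either result.

On these data alone, whether an amine, a carboxylic acid or a longer chain such as ethoxy at this position would stay within the scatter remains open. So does whether methoxy in place of fluoro gives a similar step on compound 1, which lacks the sulfamoyl group.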